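The compounds below may be only part of what the source reports. "The series", "measured", "known", "first", "only" and "open" are said of these compounds alone.

The measured compounds are compound 1 `COc1ccc(/C=C/C(=O)Nc2nc3ccc([N+](=O)[O-])cc3s2)cc1O` at 372 umol/kg, compound 2 `O=C(/C=C/c1ccc(O)cc1)Nc1nc2ccccc2s1` at 517 umol/kg, and compound 3 `O=C(/C=C/c1ccc(O)cc1)Nc1nc2ccc([N+](=O)[O-])cc2s1` at 382 umol/kg, all in a functional assay on the whole organism (Hindlimb, strain albino) with Mus musculus as the target, in the maximal electroshock model, with a stated time of 0.5 h; a higher number here means that more compound is needed for the effect, a lower number that less compound is needed.

Compound 3 and compound 2 differ by one change, (hydrogen in place of nitro on an aromatic carbon), and that step in this assay is a 1.4-fold higher number from compound 3 to compound 2 (0.13 log units; within the scatter). The same change separates compound 1 from the unmeasured compound 4 `COc1ccc(/C=C/C(=O)Nc2nc3ccccc3s2)cc1O`: hydrogen in place of nitro on an aromatic carbon. The difference between the core of compound 1 and the core of compound 3 is not broken down here. Compound 1 and compound 3 give values that lie within the scatter of each other.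

Because the step of a 1.4-fold higher number from compound 3 to compound 2 (0.13 log units; within the scatter) was within the scatter, the step from compound 1 to compound 4 is expected to be a 1.3-fold higher number from compound 1 to compound 4 (0.13 log units; within the scatter) in this assay. For compound 4 the estimate is 500 umol/kg, with a range from 250 umol/kg to 1000 umol/kg.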

Compound 4, dose for half-maximal effect: 495 umol/kg
Compound 4: the middle estimate sits 1.0-fold (0.00 log units) above what was measured; measured number inside the range.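

In this assay, hydrogen in place of nitro on the core of compound 1 gives a 1.3-fold higher number from compound 1 to compound 4 (0.12 log units; within the scatter), and this agrees with the same change on the other core: the same change on two cores in this assay, a 1.4-fold higher number (0.13 log units; within the scatter) from compound 3 to compound 2 and a 1.3-fold higher number (0.12 log units; within the scatter) from compound 1 to compound 4, 1.0-fold (0.01 log units) apart, within the scatter of two such steps. The change therefore carries across these two cores without a detectable difference. Among the compounds shown here, since each step lies within the scatter, however, this shows only that the change has no clear effect on either core, not that a sizeable effect would transfer from one core to another, and two cores say nothing about any others.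

The compounds shown carry only nitro or hydrogen at this place, leaving open what an amine, a carboxylic acid or a chlorine atom there would give. Also open, from the compounds shown here alone, is whether any such group would produce a step beyond the scatter on either core.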